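Amide substituent change on the dihydrofuran carboxamide series

The compounds below may be only part of what the source reports. "The series", "measured", "known", "first", "only" and "open" are said of these compounds alone.

Three amides of the shared core have been run in a functional assay on HeLa cells (Homo sapiens) for cytotoxicity, read by MTT assay, with a stated time of 24 h; on this read-out lower numbers stand for stronger inhibition and higher numbers for weaker inhibition. Compound 1 `C=CC1=C(C(=O)NCCC)C(c2ccc(F)cc2)OC1` returns a limit, > 100000 nM, rather than a number. Compound 2 `C=CC1=C(C(=O)NCc2ccccc2F)C(c2ccc(F)cc2)OC1` likewise sits at a limit, > 100000 nM. Compound 3 `C=CC1=C(C(=O)Nc2ccc(C)cc2)C(c2ccc(F)cc2)OC1` also gives only a limit, > 100000 nM. The steps from compound 1 to compound 2 a step that the two limits leave unreadable from compound 1 to compound 2, from compound 1 to compound 3 a step that the two limits leave unreadable from compound 1 to compound 3 and from compound 2 to compound 3 a step that the two limits leave unreadable from compound 2 to compound 3 are all unreadable, because every value sits at the same limit (the limit of > 100000 nM in this assay, at which 3 of the 3 values shown sit).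

Compound 4 `C=CC1=C(C(=O)NCc2ccccc2)C(c2ccc(F)cc2)OC1` differs from compound 3 by benzyl in place of 4-methylphenyl on an amide-type nitrogen. Within the series the comparable swaps between chain and aryl amide substituents, from compound 1 to compound 2 and from compound 2 to compound 3, gave no readable change, so no measured step informs the direction or size of this one. With all three measured values at the limit, compound 4 is expected to stay there as well, an estimated 120000 nM with a range from 40000 nM to 400000 nM. The step from compound 3 to compound 4 is thus expected to be a step that the limit leaves unreadable from compound 3 to compound 4, with a number most likely not reported at all.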

Compound 4, half-maximal inhibitory concentration: > 100000 nM
Compound 4 ended at the assay's limit; the forecaster's own chance of this, stated with the estimate: 85%; the middle value lies beyond the limit too.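

In this assay compound 4 gives > 100000 nM as a limit. Its steps with compound 1, compound 2 and compound 3 cannot be read, because all the values sit at one limit: the limit of > 100000 nM in this assay, at which 4 of the 4 values shown sit.

The compounds shown leave open whether any amide substituent on the shared core gives a measurable value on this read-out.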